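This account rests on a few compounds, and the source may have more. Where it says the series, first, only, none or still open, it means among the compounds named here.

In an ADME assay on HEK293 cells (Homo sapiens) for cytotoxicity, read by MTT assay, with a stated time of 72 h (on this read-out higher numbers stand for weaker inhibition and lower numbers for stronger inhibition), compound 1 `COc1ccc(C2=C(c3cc(OC)c(OC)c(OC)c3)CC(O)C2=O)cc1[N+](=O)[O-]` gives > 100 ug/mL, which is a limit of the assay and not an exact number. Compound 1 therefore has no exact position on the scale. It shares its place with one other compound, as the limit of > 100 ug/mL in this assay, at which 2 of the 3 values shown sit, shows. Compound 3 `COc1ccc(C2=C(c3cc(OC)c(OC)c(OC)c3)C(=O)C(OC(C)=O)C2)cc1Cl` gives 60 ug/mL, a measured number.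

Compound 4 `COc1ccc(C2=C(c3cc(OC)c(OC)c(OC)c3)CC(O[SiH2]C(C)(C)C)C2=O)cc1[N+](=O)[O-]` differs from compound 1 by a single change: a group of 5 heavy atoms (4 carbon, 1 silicon; no ring) in place of a hydrogen atom, on an oxygen on a saturated carbon. Among the measured compounds shown here, no pair of measured compounds isolates this change, so its effect cannot be read directly from the data. The closest guide is compound 2 `COc1ccc(C2=C(c3cc(OC)c(OC)c(OC)c3)C(=O)CC2O[SiH2]C(C)(C)C)cc1OC`, which carries the same group on an oxygen on a saturated carbon. Compound 2 gives > 100 ug/mL, and this too is a limit.

On that basis, the change is expected to cause no step beyond the scatter in this assay, in either direction. The expected step is a number no higher from compound 1 to compound 4 (the limit leaves the size open). For compound 4 the estimated value is 100 ug/mL, with an expected range from 45 ug/mL to 200 ug/mL.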

Compound 4, half-maximal inhibitory concentration: > 100 ug/mL
Compound 4: no number, only a limit; the forecaster's own chance of this, stated with the estimate: 70%; the middle value lies on the limit itself.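

Among the compounds shown here, compound 1 and compound 4 each give only a limit, not a measured number, so no step between them can be read. That limit is a common result here: the limit of > 100 ug/mL in this assay, at which 3 of the 4 values shown sit.

The compounds shown leave open whether placing the silicon-bearing group on that oxygen in place of hydrogen changes the cytotoxicity at all.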